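The compounds below may be only part of what the source reports. "The series", "measured", "known", "first", "only" and "open" are said of these compounds alone.

In a functional assay on HCT-116 cells (Homo sapiens) for antiproliferative activity, read by MTT assay, with a stated time of 48 h (on this read-out higher numbers stand for weaker inhibition and lower numbers for stronger inhibition), compound 1 `COc1ccc(-c2c(Nc3ccc(F)cc3)c3ccccc3oc2=O)cc1` reads 39400 nM and compound 3 `COc1ccc(-c2c(Nc3cccc(C(F)(F)F)c3)c3ccccc3oc2=O)cc1` reads 55700 nM while compound 2 `COc1ccc(-c2c(Nc3ccc(C)c(O)c3)c3ccccc3oc2=O)cc1` reads 12300 nM as the lowest number of the three. The steps of a 3.2-fold lower number from compound 1 to compound 2 (0.51 log units; beyond the scatter) and a 4.5-fold higher number from compound 2 to compound 3 (0.66 log units; beyond the scatter) lie beyond the scatter and are modest, while a 1.4-fold higher number from compound 1 to compound 3 (0.15 log units; within the scatter) lies within it. Compared with compound 2, compound 4 `COc1ccc(-c2c(Nc3ccc(C)c(O)c3)c3ccc(OC)cc3oc2=O)cc1` has methoxy in place of hydrogen on an aromatic carbon of the shared core. All three measured steps change the group on the nitrogen and none touches this carbon, so they give only a rough scale and no direction. The expected result is a 1.2-fold lower number from compound 2 to compound 4 (0.09 log units; within the scatter) with no change beyond the scatter. For compound 4 the estimate is 10000 nM with 3500 nM to 30000 nM as the expected range.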

Compound 4, half-maximal inhibitory concentration: 26500 nM
The estimate for compound 4 lay 2.7-fold (0.42 log units) below the measured number, and the stated range covers the measured number.
By their numbers in this assay, from the lowest: compound 2; then compounds 4, 1 and 3 (each within the scatter of the next, the first and the last beyond it).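

Within the data shown here, the compounds before this one changed only the group on the nitrogen, so this is the first reading of a change on the shared core. In this assay, methoxy in place of hydrogen on this aromatic carbon gives a 2.2-fold higher number from compound 2 to compound 4 (0.33 log units; beyond the scatter), a modest weakening of inhibition that lies beyond the scatter. No available evidence explains this loss.

Going by these compounds, it remains open whether an amine or a longer chain such as ethoxy on this carbon would also weaken inhibition. On these data alone, whether methoxy has the same effect with another group on the nitrogen also remains open.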